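Methyl for bromo on the pendant ring of compound 2

The compounds below may be only part of what the source reports. "The series", "measured", "known", "first", "only" and "open" are said of these compounds alone.

Going by the values given here, compound 2 `C=CCn1c(=O)/c(=C\c2cccc(Br)c2)[nH]c(=O)/c1=C\c1ccccc1OC` stands as the lower of the two numbers measured so far: in a functional assay on MCF7 cells (Homo sapiens) for cytotoxicity, read by CCK-8 assay, with a stated time of 72 h (on this read-out lower numbers stand for stronger inhibition and higher numbers for weaker inhibition), compound 2 gives 5400 nM. Among the compounds with values here, its nearest neighbour is compound 1 `C=CCn1c(=O)/c(=C\c2cccc(F)c2)[nH]c(=O)/c1=C\c1ccccc1OC`, which in this assay gives 13700 nM; the one measured step, a 2.5-fold lower number from compound 1 to compound 2 (0.40 log units; beyond the scatter), is the replacement of fluoro by bromo on an aromatic carbon.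

Compound 3 `C=CCn1c(=O)/c(=C\c2cccc(C)c2)[nH]c(=O)/c1=C\c1ccccc1OC` has not been measured yet. It differs from compound 2 by methyl in place of bromo on an aromatic carbon, that is, 3-bromophenyl becomes 3-methylphenyl. Within the data shown here, no measured step exchanges bromo for methyl, so the only guide is that the halogen series moved in this assay by a modest amount when the group at this position grew from fluoro to bromo. Since methyl resembles bromo in the count of heavy atoms entering and leaving, the expected step is small and may stay within the scatter, if anything trending toward a slightly higher number.

On that basis compound 3 is estimated at 7500 nM, in a range from 3000 nM to 18000 nM, which corresponds to an expected step of a 1.4-fold higher number from compound 2 to compound 3 (0.14 log units; within the scatter).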

Compound 3, half-maximal inhibitory concentration: 20700 nM
Compound 3: middle estimate off by 2.8-fold (0.44 log units), on the low side; measured number outside the range, above it.
By their numbers in this assay, from the lowest: compound 2; then compounds 1 and 3 (each within the scatter of the next).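

Replacing bromo with methyl on this ring gives a 3.8-fold higher number from compound 2 to compound 3 (0.58 log units; beyond the scatter) in this assay, so the lower number of compound 2 does not carry over to a group with the same count of heavy atoms, 1 in each case. The step of a 1.5-fold higher number from compound 1 to compound 3 (0.18 log units; within the scatter) leaves compound 1 and compound 3 indistinguishable, and among the three groups tested here, only bromo stands apart, with both of its steps beyond the scatter. Nothing measured here accounts for this difference between bromo and methyl, and no supporting evidence on its origin is available.

The three compounds leave open whether the low number is particular to bromo or would also appear with chloro, iodo, or a larger group such as trifluoromethyl or methoxy, and how an amine or a carboxylic acid at this place would compare. They also leave open whether the preference for bromo over methyl would hold if the other parts of the shared core were changed, since the allyl chain and the second benzylidene group stay the same throughout.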